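Swapping the anilino ring on compound 3

This account rests on a few compounds, and the source may have more. Where it says the series, first, only, none or still open, it means among the compounds named here.

Of the compounds shown here, three have been measured in a functional assay on ECa-109 cells (Homo sapiens) for inhibition, read by MTT assay, with a stated time of 72 h; on this read-out higher numbers stand for weaker inhibition and lower numbers for stronger inhibition. Compound 1 `C#CCSc1nc(Nc2ccc(OC)cc2)c(C#N)c(-c2ccccc2)n1` gives 23200 nM in this assay. Compound 2 `C#CCSc1nc(Nc2cccc(Cl)c2)c(C#N)c(-c2ccccc2)n1` reaches only a limit of this assay, > 128000 nM. Going by the values given here, the step of an at least 5.5-fold higher number from compound 1 to compound 2 (0.74 log units; beyond the scatter) is the one measured change on the nitrogen that carries the aryl ring, and its size can only be bounded, given (the limit of > 128000 nM in this assay, at which 1 of the 3 values shown sits). Compound 3 `N#Cc1c(Nc2ccc(Cl)cc2)nc(SCc2cn(Cc3ccccc3Cl)nn2)nc1-c1ccccc1`, which also differs from the other two in the group on the shared core, gives 1420 nM in this assay, the lowest of the numbers shown, with compound 1 the nearest and clearly separated from it.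

Compound 4 `Cc1cccc(Nc2nc(SCc3cn(Cc4ccccc4Cl)nn3)nc(-c3ccccc3)c2C#N)c1` differs from compound 3 in one place: 3-methylphenyl in place of 4-chlorophenyl on a nitrogen on an aromatic ring. The step bearing on this change is the one from 4-methoxyphenyl to 3-chlorophenyl, which raised the number by at least a modest amount; the present change likewise goes from 4-chlorophenyl to 3-methylphenyl, though with methyl rather than chlorine entering, so a modest rise in the number is expected, a 2.5-fold higher number from compound 3 to compound 4 (0.39 log units; beyond the scatter). Compound 4 is therefore estimated to give 3500 nM, within 1200 nM to 12000 nM.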

Compound 4, half-maximal inhibitory concentration: 15600 nM
Compound 4: middle estimate off by 4.5-fold (0.65 log units), on the low side; measured number outside the range, above it.
By their numbers in this assay, from the lowest: compound 3; then compounds 4 and 1 (each within the scatter of the next). At a limit, above all of these: compound 2.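

In this assay, the swap on the nitrogen gives an 11-fold higher number from compound 3 to compound 4 (1.04 log units; beyond the scatter), a step of full measured size, whereas the earlier change at this position could only be bounded. It shows that this position still strongly affects the read-out with the group on the shared core that compound 3 carries, even though 4-chlorophenyl and 3-methylphenyl match in heavy-atom count. Nothing given here accounts for the size of this step.

The step changes both the substituent and its place on the ring, and the compounds shown do not separate the two. Also open, from the compounds shown here alone, is how this nitrogen would read with the rest of compound 3 kept and an unsubstituted phenyl, a 4-methylphenyl or an amine-bearing phenyl ring in place of 4-chlorophenyl.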